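A few compounds are considered here, and "the series" means these few. Any claim that something is new, unique, unknown or untested is made for them only; others in the source may bear on it.

Compound 1, `COc1cc(CNc2cc(Br)cc3[nH]ncc23)c([N+](=O)[O-])cc1OC`: 1040 nM
Compound 2, `O=C(O)CNc1cccc(CNc2cc(C(F)(F)F)cc3[nH]ncc23)c1`: > 100000 nM
Compound 3, `Cc1ccc(CNc2cc(C(F)(F)F)cc3[nH]ncc23)c([N+](=O)O)c1`: 620 nM

All three share the same core and differ in the groups carried on the benzylic ring. In an assay for inhibition of Tryptophan 2,3-dioxygenase (Homo sapiens), with stated times of 10 min and 60 min (a higher number here means a weaker inhibitor, a lower number a stronger inhibitor), compound 1 gives 1040 nM, while compound 3 gives 620 nM. Compound 2 stands apart: for it the assay returned only a limit, > 100000 nM, not a number, so compound 2 sits at the limit of > 100000 nM in this assay, at which 1 of the 3 values shown sits. Nothing more is known about how far beyond that limit it lies.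

Compound 4, `Nc1cccc(CNc2cc(C(F)(F)F)cc3[nH]ncc23)c1`, is compound 2 with a small cut: hydrogen in place of carboxymethyl on a nitrogen on an aromatic ring. Among the compounds with values here, no pair of measured compounds differing in one place is available, so the size of this step cannot be read from a neighbour. Since compound 2 is only a limit, the step can only be guessed. Compound 3 giving 620 nM and compound 1 giving 1040 nM show that the shared core can inhibit well when the benzylic ring is decorated differently, so the expectation is a step from compound 2 to compound 4 of an at least 5.0-fold lower number from compound 2 to compound 4 (0.69 log units; beyond the scatter) toward stronger inhibition, though with wide uncertainty. Compound 4 is estimated at 20000 nM, with a likely range from 3000 nM to 100000 nM.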

Compound 4, half-maximal inhibitory concentration: 2510 nM
Beside the measured number, compound 4's estimate is 8.0-fold (0.90 log units) above it; the measured number lies below the stated range.
By their numbers in this assay, from the lowest: compounds 3 and 1 (each within the scatter of the next); then compound 4. At a limit, above all of these: compound 2.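

In this assay, putting hydrogen in place of carboxymethyl on a nitrogen on an aromatic ring gives an at least 39-fold lower number from compound 2 to compound 4 (1.60 log units; beyond the scatter). This is the first single change shown at this nitrogen, and it reveals that going from (carboxymethyl)amino to amino is enough to turn a compound without a measurable number into one with a real number. Compound 2 is only a limit, so the true size of the step stays unknown: the limit of > 100000 nM in this assay, at which 1 of the 4 values shown sits.

From the compounds shown here alone, what remains open is whether the carboxylic acid or the chain that carries it accounts for the step, which a methyl ester or a longer chain ending in a carboxylic acid on this nitrogen could help to separate. Also open, going by these compounds, is where a simple methyl or acetyl group on this nitrogen would fall relative to compound 4.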